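Hydroxy added to the methoxyphenyl hydrazone of compound 2

The source may report more compounds than this note shows. Statements on the series, on what has been measured and on what is new or still open speak of the compounds shown alone.

Measured compounds:
compound 1, `CN(C)C(=O)C[C@H](CSc1ccccc1)Nc1c(C(=O)N/N=C/c2ccc(Br)s2)cnc2c(C(F)(F)F)cccc12`, an ADME assay on Vero cells (Chlorocebus sabaeus) for cytotoxicity, read by MTT assay, with a stated time of 72 h; a higher number here means a weaker inhibitor, a lower number a stronger inhibitor: > 62.5 ug/mL
compound 2, `COc1ccc(/C=N/NC(=O)c2cnc3ccc(F)cc3c2N[C@@H](CSc2ccccc2)CC(=O)N(C)C)cc1`, this assay: "not determined" (no result reported)

Two compounds of this series carry a result in this assay. For compound 1 the value of > 62.5 ug/mL is a limit of the assay and not a number. Compound 2 has no result in this assay; its entry reads "not determined" (no result reported), so it stands nowhere on the numbers shown, and the only anchor is the limit of > 62.5 ug/mL in this assay, at which 1 of the 2 values shown sits.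

Compound 3, `COc1ccc(/C=N/NC(=O)c2cnc3ccc(F)cc3c2N[C@@H](CSc2ccccc2)CC(=O)N(C)C)cc1O`, has not been measured. It differs from compound 2 by hydroxy in place of hydrogen on an aromatic carbon: a hydroxy in place of hydrogen on an aromatic carbon, turning the 4-methoxyphenyl into a 3-hydroxy-4-methoxyphenyl.

Among the measured compounds shown here, no step between measured compounds exists for this pair, so the size of the change from compound 2 to compound 3 in this assay cannot be read from the data. Since compound 1 also sits at the limit, the step is expected to be none beyond the scatter, with the result most likely again reported as a limit rather than a number. Compound 3 is therefore estimated at 70 ug/mL, in a range from 30 ug/mL to 150 ug/mL.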

Compound 3, half-maximal inhibitory concentration: > 62.5 ug/mL
Compound 3: no number, only a limit; the forecaster's own chance of this, stated with the estimate: 70%; the middle value is on the limit's open side.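

No step can be read between compound 2 and compound 3 in this assay. Compound 3 gives > 62.5 ug/mL, which is a limit and not a number. The compounds shown leave open what number any of them would reach, and whether the added hydroxy alters the result at all: the limit of > 62.5 ug/mL in this assay, at which 2 of the 3 values shown sit.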